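Compound 3 to compound 4: a change of phenyl group

The compounds below may be only part of what the source reports. "The series", "measured", "known", "first", "only" and "open" are said of these compounds alone.

compound 1 (`Cc1ccc(Nc2ncc(C(F)(F)F)c(N3Cc4cccc(N(C)S(C)(=O)=O)c4C3)n2)cc1C`) gives > 30000 nM (a limit of the assay)
compound 2 (`COc1ccc(C(F)(F)F)cc1Nc1ncc(C(F)(F)F)c(N2Cc3cccc(N(C)S(C)(=O)=O)c3C2)n1`) gives 17200 nM (a measured number)
compound 3 (`COc1cc(Nc2ncc(C(F)(F)F)c(N3Cc4cccc(N(C)S(C)(=O)=O)c4C3)n2)c(OC)cc1Cl`) gives 16500 nM (a measured number)

These values come from a functional assay on HeLa cells (Homo sapiens) for antiproliferative activity, read by spectrophotometry, with a stated time of 2 days (on this read-out lower numbers stand for stronger inhibition of growth and higher numbers for weaker inhibition of growth), and show growth inhibition only at high concentrations. The entry for compound 1 is a limit and not a number. Among the compounds with values here, compound 3 therefore has one of only two real numbers, and its nearest neighbour gives a 1.0-fold lower number from compound 2 to compound 3 (0.02 log units; within the scatter) (within the scatter), so compound 2 and compound 3 stand level.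

Compound 4 (`COc1cc(Nc2ncc(C(F)(F)F)c(N3Cc4cccc(N(C)S(C)(=O)=O)c4C3)n2)cc(OC)c1`) carries 3,5-dimethoxyphenyl in place of 4-chloro-2,5-dimethoxyphenyl on a nitrogen on an aromatic ring, while the shared core stays the same. Every measured step changes the group at this same place. Those starting from compound 1 give only floors: an at least 1.7-fold lower number from compound 1 to compound 2 (0.24 log units; that floor lies within the scatter) and an at least 1.8-fold lower number from compound 1 to compound 3 (0.25 log units; that floor lies within the scatter) both stay within the scatter. Within the data shown here, none of the measured steps swaps exactly these two groups, so the estimate rests on this general flatness. No step beyond the scatter is expected, and the estimated change is a 1.1-fold higher number from compound 3 to compound 4 (0.04 log units; within the scatter) (within the scatter). Compound 4 could also reach the limit of the assay, as compound 1 did. The estimated value for compound 4 is 18000 nM (expected range 8000 nM to 30000 nM).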

Compound 4, concentration for 50% growth inhibition: 7000 nM
Beside the measured number, compound 4's estimate is 2.6-fold (0.41 log units) above it, outside the stated range (below it).
By their numbers in this assay, from the lowest: compound 4; then compounds 3 and 2 (each within the scatter of the next). At a limit, above all of these: compound 1.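

In this assay, this group on the nitrogen now makes a difference beyond the scatter, which no measured pair among the earlier compounds had shown: a 2.4-fold lower number from compound 3 to compound 4 (0.37 log units; beyond the scatter) and a 2.5-fold lower number from compound 2 to compound 4 (0.39 log units; beyond the scatter) are both modest steps towards stronger inhibition of growth. The position is therefore not as flat as compound 2 and compound 3 suggested, although the two methoxy groups of compound 4 are also present in compound 3, so this step alone does not separate the loss of the chlorine from the different placing of the methoxy groups. The step of an at least 4.2-fold lower number from compound 1 to compound 4 (0.63 log units; beyond the scatter) is also beyond the scatter, but it is only a floor, as compound 1 stands at a limit of the assay: the limit of > 30000 nM in this assay, at which 1 of the 4 values shown sits.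

The compounds shown leave open whether a phenyl group carrying a single methoxy group, or an amine such as morpholine, would lower the number further. They also leave open how any other part of the shared core contributes, as every step here changes the same group on the same nitrogen.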